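This account rests on a few compounds, and the source may have more. Where it says the series, first, only, none or still open, it means among the compounds named here.

Compound 1 `Cc1nc(C)c(C(=O)Oc2ccc(/C=C/C(=O)O)cc2O)nc1C` gives 84600 nM in a functional assay on a cell-free system (Platelet, plasma, Oryctolagus cuniculus) for inhibition, with a stated time of 5 min, at 37 degrees C; on this read-out lower numbers stand for stronger inhibition and higher numbers for weaker inhibition. Compound 2 `CCOC(=O)/C=C/c1cc(Cl)ccc1OC(=O)c1nc(C)c(C)nc1C` gives 67100 nM. Compound 3 `CCOC(=O)/C=C/c1ccc(OC(=O)c2nc(C)c(C)nc2C)c(O)c1` gives 77400 nM.

These three numbers sit close together. The step of a 1.1-fold lower number from compound 1 to compound 3 (0.04 log units; within the scatter) is within the scatter, and the values of compound 3 and compound 2 also differ only within the scatter, so none of the three can be called stronger or weaker than the others. Compound 4 `CCOC(=O)/C=C/c1ccc(OC(=O)c2nc(C)c(C)nc2C)c(OC)c1` has not yet been measured. It differs from compound 3 in one place: methyl in place of hydrogen on an oxygen on an aromatic ring. Among the measured compounds shown here, only one measured step exists to compare with, a 1.1-fold lower number from compound 1 to compound 3 (0.04 log units; within the scatter), and it concerns a different oxygen, the one next to a carbonyl group; it left the number unchanged within the scatter. For the measured compounds named here, no measured pair shows a hydroxy turned into a methoxy on an aromatic ring, so nothing points either way, and no step beyond the scatter is expected in this assay. For compound 4 the expected value is 75000 nM, with a range from 30000 nM to 200000 nM, which amounts to an expected step of a 1.0-fold lower number from compound 3 to compound 4 (0.01 log units; within the scatter).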

Compound 4, half-maximal inhibitory concentration: 58400 nM
Compound 4: middle estimate off by 1.3-fold (0.11 log units), on the high side; the measured number falls inside the stated range.
By their numbers in this assay, from the lowest: compounds 4, 2, 3 and 1 (each within the scatter of the next).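

In this assay, the change from hydroxy to methoxy on an oxygen on an aromatic ring gives a 1.3-fold lower number from compound 3 to compound 4 (0.12 log units; within the scatter), so this step does not move the number beyond the scatter. Among the compounds shown here, the earlier step concerned a different oxygen, the one next to a carbonyl group, so this is the first sign that a methyl can take the place of hydrogen on the aromatic oxygen without a clear change in this read-out. Nothing available explains this outcome.

As far as these compounds go, whether a longer chain on this oxygen, or an amine in place of the hydroxy, would leave the number within the same range remains open. The compounds shown also include no change that moves the number in this assay beyond the scatter, so what would make these compounds clearly stronger or weaker remains unknown.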